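Aryl variation on the two-carbon chain of the shared core

The source may report more compounds than this note shows. Statements on the series, on what has been measured and on what is new or still open speak of the compounds shown alone.

Compound 1 `CCc1nc(Cl)c2n1CCN([C@@H](C(=O)NC)c1ccccc1)[C@H]2COc1ccc(C(F)(F)F)cc1` and compound 2 `CCc1nc(Cl)c2n1CCN([C@@H](C(=O)NC)c1ccccc1)[C@H]2CCc1cc(F)c(C(F)(F)F)cc1F` share the same core and differ in the group carried on the chain. In a functional assay on CHO cells for antagonist activity at Orexin receptor type 2 (Homo sapiens), read by FLIPR and calcium flux (on this read-out lower numbers stand for stronger inhibition and higher numbers for weaker inhibition), compound 1 gives 9 nM and compound 2 gives 17 nM. Compound 2 holds the higher of the two numbers, but the gap to compound 1 lies within the scatter, so the two read as equivalent. Compound 3 `CCc1nc(Cl)c2n1CCN([C@@H](C(=O)NC)c1ccccc1)[C@H]2CCc1cccc(C(F)(F)F)c1F` remains to be measured; against compound 2 the change is 2-fluoro-3-(trifluoromethyl)phenyl in place of 2,5-difluoro-4-(trifluoromethyl)phenyl on a saturated chain carbon, two bonds along the chain from a saturated ring carbon. For the measured compounds named here, no measured pair isolates a change of this kind, so no direction is established. Because compound 1 at 9 nM and compound 2 at 17 nM sit close together despite different aryl groups on the chain, the expected step is a 1.2-fold higher number from compound 2 to compound 3 (0.07 log units; within the scatter), in either direction and not beyond the scatter. Compound 3 is estimated at 20 nM, with a range from 7 nM to 60 nM in this assay.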

Compound 3, half-maximal inhibitory concentration: 9 nM
Compound 3: the middle estimate sits 2.2-fold (0.35 log units) above what was measured, within the range that was stated.
By their numbers in this assay, from the lowest: compounds 1, 3 and 2 (each within the scatter of the next).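

In this assay, for the compounds shown here, 2-fluoro-3-(trifluoromethyl)phenyl in place of 2,5-difluoro-4-(trifluoromethyl)phenyl on a saturated chain carbon gives a 1.9-fold lower number from compound 2 to compound 3 (0.28 log units; within the scatter) and so reads as equivalent, which is the first measured pair to isolate an aryl exchange at this position. 2-Fluoro-3-(trifluoromethyl)benzyl in place of 4-(trifluoromethyl)phenoxy gives no change at the digits printed from compound 1 to compound 3 (within the scatter) and thus adds a second equivalent exchange, so all three groups on the chain of the shared core read alike. No supporting data are available to explain this equivalence.

Going by these compounds, all three compounds carry a fluorinated aryl group on a short chain, so the effect of a carboxylic acid, an amine or a longer chain at this position remains open. On these data alone, it is also open whether any group here separates from the others beyond the scatter.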